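The source may report more compounds than this note shows. Statements on the series, on what has been measured and on what is new or still open speak of the compounds shown alone.

The shared core of compound 1 `O=C(Nc1ccc(Cl)c(-c2nnc3c(Cl)cccn23)c1)c1cccc(Cl)c1` carries an amide whose carbonyl bears a 3-chlorophenyl group; in a functional assay on U-251 cells (Homo sapiens) for antiproliferative activity, read by MTT assay, with a stated time of 72 h (a lower number here means a stronger inhibitor, a higher number a weaker inhibitor), compound 1 gives 43100 nM. Compound 2 `O=C(Nc1ccc(Cl)c(-c2nnc3c(Cl)cccn23)c1)c1c(F)cccc1Cl` carries 2-chloro-6-fluorophenyl in place of 3-chlorophenyl on the carbonyl carbon. In this assay compound 2 reaches only a limit of the assay, > 100000 nM. Compound 3 `O=C(Nc1ccc(Cl)c(-c2nnc3c(Cl)cccn23)c1)c1ccc(Cl)cc1Cl` carries 2,4-dichlorophenyl at the same place. In this assay compound 3 likewise reaches only a limit, > 100000 nM. So compound 3 sits at the upper edge of what the assay reports, with an at least 2.3-fold higher number from compound 1 to compound 3 (0.36 log units; beyond the scatter), while a step that the two limits leave unreadable from compound 2 to compound 3; two of the three values sit at the limit (the limit of > 100000 nM in this assay, at which 2 of the 3 values shown sit).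

Compound 4 `O=C(Nc1ccc(Cl)c(-c2nnc3c(Cl)cccn23)c1)c1cccnc1` differs from compound 3 by pyridin-3-yl in place of 2,4-dichlorophenyl on a carbonyl carbon. Going by the values given here, the steps that bear on a change at the carbonyl carbon are an at least 2.3-fold higher number from compound 1 to compound 2 (0.36 log units; beyond the scatter) and an at least 2.3-fold higher number from compound 1 to compound 3 (0.36 log units; beyond the scatter), both moving away from 3-chlorophenyl toward the limit, and the step from compound 2 to compound 3 remains unreadable. With a six-membered ring holding a single hetero atom and no chlorine, compound 4 is expected to fall back toward the number seen for compound 1 rather than stay at the limit. The expected step is an at least 1.4-fold lower number from compound 3 to compound 4 (0.15 log units; that floor lies within the scatter). Compound 4 is therefore estimated at 70000 nM, within 30000 nM to 150000 nM, with a real chance that only a limit is reported.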

Compound 4, half-maximal inhibitory concentration: > 100000 nM
Compound 4: no number, only a limit (the forecaster's own chance of this, stated with the estimate: 45%); at least 1.4-fold (0.15 log units) between middle value and limit.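

Compound 4 shows that, on a carbonyl carbon whose other neighbours are amide-type nitrogen, the loss relative to 3-chlorophenyl is not confined to the chlorine-bearing phenyl groups: pyridin-3-yl, with a hetero atom in its ring and no chlorine, gives an at least 2.3-fold higher number from compound 1 to compound 4 (0.36 log units; beyond the scatter). Compound 1 therefore remains the only one of the four with a number in this assay. The steps among compound 2, compound 3 and compound 4 cannot be read, because all three stop at the same limit: the limit of > 100000 nM in this assay, at which 3 of the 4 values shown sit.

The compounds shown leave open whether any group on this carbonyl carbon can bring the number below that of compound 1. They also do not show how an amine, a carboxylic acid or a longer chain at this place would read in this assay.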